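A few compounds are considered here, and "the series" means these few. Any claim that something is new, unique, unknown or untested is made for them only; others in the source may bear on it.

The compounds share one core, on which an aromatic amine substituent is varied. Compound 1 `Cc1ccc(NC2=CC(=O)c3c(nc4n3[C@H]3OC[C@@H](O)[C@H]3OC4)C2=O)cc1C` carries a 3,4-dimethylphenyl group on that amine nitrogen; in a functional assay on ECa-109 cells for inhibition, with ECa-109 cell line (Homo sapiens) as the target, read by sulforhodamine B assay (a higher number here means a weaker inhibitor, a lower number a stronger inhibitor), compound 1 gives 4090 nM. Compound 3 `CCOc1ccccc1NC1=CC(=O)c2c(nc3n2[C@H]2OC[C@@H](O)[C@H]2OC3)C1=O` carries a 2-ethoxyphenyl group there, and in this assay compound 3 gives 4320 nM; the step of a 1.1-fold higher number from compound 1 to compound 3 (0.02 log units; within the scatter) lies within the scatter. Compound 2 `COc1ccccc1NC1=CC(=O)c2nc3n(c2C1=O)[C@H]1OC[C@@H](O)[C@H]1OC3` carries a 2-methoxyphenyl group. For compound 2, this assay reports only a limit, > 4000 nM, and no number, because compound 2 sits at the limit of > 4000 nM in this assay, at which 1 of the 3 values shown sits. Compound 4 `COc1cccc(NC2=CC(=O)c3nc4n(c3C2=O)[C@H]2OC[C@@H](O)[C@H]2OC4)c1` is not yet measured and differs from compound 2 in one place: 3-methoxyphenyl in place of 2-methoxyphenyl on an amine nitrogen. For the measured compounds named here, no measured pair covers this exact exchange. Going by the values given here, the one measured step, between two other aryl groups, stayed within the scatter, and all three known compounds are weak inhibitors in this assay. The expected step is a step that the limit leaves unreadable from compound 2 to compound 4, meaning nothing beyond the scatter. The estimated value for compound 4 in this assay is 4500 nM, within a range from 2000 nM to 10000 nM, with a fair chance that only a limit is reported again.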

Compound 4, half-maximal inhibitory concentration: 7620 nM
Estimate against measurement, compound 4: 1.7-fold (0.23 log units) below; the range from low to high includes it.
By their numbers in this assay, from the lowest: compounds 1, 3 and 4 (each within the scatter of the next).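

The step from compound 2 to compound 4 cannot be read, because compound 2 has only a limit and no number: the limit of > 4000 nM in this assay, at which 1 of the 4 values shown sits.

The compounds shown leave open whether 3-methoxyphenyl and 2-methoxyphenyl on the amine nitrogen differ at all in this assay.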